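The source may hold more compounds than are shown below. What is called first, only, known or untested is meant among the compounds shown, and "the series" means these compounds.

Compound 3 `O=C(NO)c1cnc(N2CCN(S(=O)(=O)c3ccc(F)cc3)CC2)s1` is one of three compounds with a number in a functional assay on MCF7 cells (Homo sapiens) for antiproliferative activity; on this read-out lower numbers stand for stronger inhibition of growth and higher numbers for weaker inhibition of growth. In this assay compound 3 gives 3500 nM, the second highest of the three numbers. Compound 1 `COc1ccc(S(=O)(=O)N2CCN(c3ncc(C(=O)NO)s3)CC2)cc1OC` is its nearest neighbour; in this assay compound 1 gives 2000 nM, within the scatter of compound 3. Among the compounds with values here, the furthest is compound 2 `O=C(NO)c1cnc(N2CCN(S(=O)(=O)c3ccccc3)CC2)s1`, which in this assay gives 10000 nM; the single step between measured compounds is a 2.9-fold lower number from compound 2 to compound 3 (0.46 log units; beyond the scatter).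

Compound 4 `O=C(/C=C/c1cnc(N2CCN(S(=O)(=O)c3ccc(F)cc3)CC2)s1)NO` differs from compound 3 in one place: 2-(hydroxycarbamoyl)ethenyl in place of hydroxycarbamoyl on an aromatic carbon. Within the data shown here, no measured step bears on this change. Among the measured compounds shown here, the only step in hand, fluoro in place of hydrogen on an aromatic carbon, concerns a different part of the molecule, and the hydroxycarbamoyl group is the same in every measured compound, so the data give no guide to lengthening it by two carbons into 2-(hydroxycarbamoyl)ethenyl.

With nothing to rest on, the expectation is a number close to compound 3, with a broad range either way. Compound 4 is therefore estimated at 1500 nM in this assay, between 400 nM and 6000 nM, meaning an expected step of a 2.3-fold lower number from compound 3 to compound 4 (0.37 log units; beyond the scatter), which may well stay within the scatter.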

Compound 4, concentration for 50% growth inhibition: 2500 nM
Beside the measured number, compound 4's estimate is 1.7-fold (0.22 log units) below it; the measured number falls inside the stated range.
By their numbers in this assay, from the lowest: compounds 1, 4 and 3 (each within the scatter of the next); then compound 2.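

In this assay, replacing hydroxycarbamoyl with 2-(hydroxycarbamoyl)ethenyl on the aromatic carbon next to the ring sulfur gives a 1.4-fold lower number from compound 3 to compound 4 (0.15 log units; within the scatter), so this change leaves the number within the scatter. Within the data shown here, this is the first information about this position, as the hydroxycarbamoyl group was the same in all the earlier compounds, and it shows that, with the rest of compound 3 held constant, the read-out tolerates two further carbons and an added double bond outside aromatic rings at this place. No evidence at hand speaks to why the number holds across this change.

The compounds shown leave open whether the same change would also stay within the scatter on the cores of compound 1 and compound 2, where the group on the sulfonyl differs from that of compound 3. They also leave open what a saturated ethyl chain in place of the ethenyl link, a longer chain bearing the hydroxycarbamoyl group, or a carboxylic acid or primary amide in place of hydroxycarbamoyl would do at this position.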